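Lengthening the amine chain on an allyloxy benzamide

The source may hold more compounds than are shown below. What is called first, only, known or untested is meant among the compounds shown, and "the series" means these compounds.

Compound 1, with structure `CCCCCNc1cccc(NC(=O)c2ccc(OCCC)cc2)n1`, was tested in an in vitro assay on HEK-tsA201 cells for antagonist activity at Neuronal acetylcholine receptor; alpha3/beta4 (Homo sapiens), read by fluorescence and calcium flux; on this read-out higher numbers stand for weaker inhibition and lower numbers for stronger inhibition. In this assay compound 1 gives > 100000 nM, which is a limit of the assay rather than a number. Compound 2, with structure `CCCCCCNc1cccc(NC(=O)c2ccc(OCCC)cc2)n1`, likewise gives > 100000 nM in this assay, again a limit. The two differ by methyl in place of hydrogen on a saturated chain carbon, five bonds along the chain from a nitrogen on an aromatic ring, and the step that the two limits leave unreadable from compound 1 to compound 2 cannot be sized. Both of these values sit at the limit of > 100000 nM in this assay, at which 2 of the 3 values shown sit. For the measured compounds named here, compound 3, with structure `C=CCOc1ccc(C(=O)Nc2cccc(NCCC)n2)cc1`, gives 11700 nM in this assay, the only measured number among the three. The difference between the core of compound 3 and the core of compound 1 is not broken down here.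

Compound 4, with structure `C=CCOc1ccc(C(=O)Nc2cccc(NCCCC)n2)cc1`, has not yet been measured. It differs from compound 3 by methyl in place of hydrogen on a saturated chain carbon, three bonds along the chain from a nitrogen on an aromatic ring. This is the same kind of change as that from compound 1 to compound 2, but not the same: there the added carbon sits five bonds along the chain from the ring nitrogen, here three bonds along it. Since the earlier step is unreadable, nothing measured shows what adding one chain carbon does. The step from compound 3 to compound 4 is expected to be a 2.1-fold higher number from compound 3 to compound 4 (0.33 log units; beyond the scatter). This expectation rests on compound 3, whose value 11700 nM is the only anchor, with wide uncertainty. Compound 4 is estimated at 25000 nM, between 7000 nM and 100000 nM.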

Compound 4, half-maximal inhibitory concentration: 19200 nM
For compound 4 the middle estimate is 1.3-fold (0.11 log units) above the measured one; the range from low to high includes it.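

In this assay, replacing propyl with butyl on the core of compound 3 gives a 1.6-fold higher number from compound 3 to compound 4 (0.22 log units; within the scatter), so this added carbon, three bonds along the chain from the nitrogen on the aromatic ring, has no effect that can be told apart from the ordinary spread of repeated measurements. For the compounds shown here, on the core of compound 1, the related one-carbon step lies five bonds along the chain and cannot be read, since compound 1 and compound 2 both sit at a limit, which is not a number: the limit of > 100000 nM in this assay, at which 2 of the 4 values shown sit. The two cores therefore offer no pair of readable steps to compare, and the data show neither that the effect of adding a chain carbon carries from one core to the other nor that it fails to.

What the compounds shown leave open is whether a propyl or butyl chain on the core of compound 1 would give a measured number, which would allow the same change to be compared directly on both cores. On these data alone, it also remains open whether a pentyl or hexyl chain, or a chain ending in an amine or a carboxylic acid, on the core of compound 3 would move the value beyond the scatter.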